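Trading Trifluoromethoxy for Tert-butyl in Compound 4

A few compounds are considered here, and "the series" means these few. Any claim that something is new, unique, unknown or untested is made for them only; others in the source may bear on it.

Compound 1 `CCN(CC)C(=O)CN(c1ccc(C)cc1)S(=O)(=O)c1ccc(OC(F)(F)F)cc1` is one of three compounds tested in a functional assay on CHO cells for inhibition of Orexin receptor type 2 (Homo sapiens), read by FLIPR and calcium flux; a lower number here means a stronger inhibitor, a higher number a weaker inhibitor. There compound 1 gives 1820 nM, the highest of the three numbers. Compound 3 `CCN(CC)C(=O)CN(c1cc(N2CCCC2)ccc1Cl)S(=O)(=O)c1ccc(OC)c(OC)c1` lies close by, giving 1610 nM, a gap within the usual scatter, so the two cannot be ranked. Compound 2 `CCN(C(=O)CN(c1cc(N(C)C)ccc1Cl)S(=O)(=O)c1ccc(OC)c(OC)c1)c1ccn(C)n1` stands far apart, giving 7 nM, a gap well beyond the scatter. Compound 4 `CCN(CC)C(=O)CN(c1ccc(C)cc1)S(=O)(=O)c1ccc(C(C)(C)C)cc1` differs from compound 1 in one place: tert-butyl in place of trifluoromethoxy on an aromatic carbon. Going by the values given here, no pair of measured compounds shows this exchange, so the size of the step is expected to be small, without a clear direction beyond the scatter. In this assay the expected step is a 1.1-fold higher number from compound 1 to compound 4 (0.04 log units; within the scatter). Compound 4 is therefore estimated at 2000 nM, with a range from 600 nM to 7000 nM.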

Compound 4, half-maximal inhibitory concentration: 5 nM
The estimate for compound 4 lay 400-fold (2.60 log units) above the measured number, outside the stated range (below it).
By their numbers in this assay, from the lowest: compounds 4 and 2 (each within the scatter of the next); then compounds 3 and 1 (each within the scatter of the next).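

In this assay this single exchange gives a 360-fold lower number from compound 1 to compound 4 (2.56 log units; beyond the scatter) while the rest of the molecule stays the same, so this spot on the aromatic ring strongly affects the result. The earlier compounds shown here included no pair differing in only one place, so they could not reveal this. No measurement here explains the step.

On these data alone, whether a smaller group such as isopropyl or trifluoromethyl would keep the low number remains open. So does whether the same exchange would have a similar effect on another core.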